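The source may hold more compounds than are shown below. What is called first, only, known or untested is meant among the compounds shown, and "the series" means these compounds.

Of the compounds shown here, two have been measured in an assay on Midbrain with Type-2 angiotensin II receptor (Rattus norvegicus) as the target; on this read-out lower numbers stand for stronger inhibition and higher numbers for weaker inhibition. Compound 1 `CCCc1nc2c(C)ccnc2n1Cc1ccc(OC(C(=O)O)c2ccccc2)cc1` gives 3400 nM, while compound 2 `C=CCc1cc(Cn2c(CC)nc3c(C)cc(C)nc32)ccc1OC(C(=O)O)c1ccccc1` gives 270 nM, the lowest of the two numbers, with the gap to compound 1 lying beyond the usual scatter. Compound 3 `CCOc1cc(Cn2c(CC)nc3c(C)cc(C)nc32)ccc1OC(C(=O)O)c1ccccc1` is still unmeasured; it differs from compound 2 by ethoxy in place of allyl on an aromatic carbon. Going by the values given here, no step between measured compounds is known in this assay, so the size of this change is open. Compound 3 is expected to stay near compound 2, with a modest weakening as the more likely direction; the estimate for compound 3 is 450 nM, ranging from 130 nM to 1500 nM. That expectation means a step of a 1.7-fold higher number from compound 2 to compound 3 (0.22 log units; within the scatter).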

Compound 3, half-maximal inhibitory concentration: 1200 nM
Estimate against measurement, compound 3: 2.7-fold (0.43 log units) below; measured number inside the range.
By their numbers in this assay, from the lowest: compound 2; then compound 3; then compound 1.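

In this assay, the position on the aromatic carbon ortho to a carboxy(phenyl)methoxy group proves sensitive to the group it carries: ethoxy in place of allyl gives a 4.4-fold higher number from compound 2 to compound 3 (0.65 log units; beyond the scatter). Both groups have 3 heavy atoms, so an equal count does not make them interchangeable here. No measurement shown accounts for this step.

From the compounds shown here alone, it remains open whether the entering oxygen or the departing double bond matters more. A propyl group at this position could separate the two, and a methoxy group would test a shorter chain.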